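The source may hold more compounds than are shown below. What is called first, only, known or untested is meant among the compounds shown, and "the series" means these compounds.

In a functional assay on MCF7 cells (Homo sapiens) for antiproliferative activity, read by MTT assay, with a stated time of 72 h (on this read-out lower numbers stand for stronger inhibition and higher numbers for weaker inhibition), compound 3 `CC1=CC[C@H]2[C@H](CC[C@]2(C)O)C(C)(C)[C@@H]1CC[C@H]1[C@]2(C)CC/C(=N/O)C(C)(C)O[C@H]2CC[C@@]1(C)O` gives 46800 nM, the higher of the two actual numbers in this set. Compound 2 `CC1=CC[C@H]2[C@@H]1CC=C(C)[C@@H](CC[C@H]1[C@]3(C)CC[C@H](OC(=O)c4ccc(Cl)cc4)C(C)(C)O[C@H]3CC[C@@]1(C)O)C2(C)C` gives 22000 nM, a lower number. Compound 1 `CC1=CC[C@H]2[C@@H]1CC=C(C)[C@@H](CC[C@H]1[C@]3(C)CC[C@H](OC(=O)c4ccncc4)C(C)(C)O[C@H]3CC[C@@]1(C)O)C2(C)C` is reported only as a limit, > 50000 nM.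

Compound 4 `CC1=CC[C@H]2[C@H](CC[C@]2(C)O)C(C)(C)[C@@H]1CC[C@H]1[C@]2(C)CC/C(=N/OC(=O)c3ccccc3)C(C)(C)O[C@H]2CC[C@@]1(C)O` follows from compound 3 through one change: benzoyl in place of hydrogen on an oxygen, or hydroxy to benzoyloxy. Within the data shown here, the one measured step that bears on this is an at least 2.2-fold lower number from compound 1 to compound 2 (0.35 log units; beyond the scatter), where 4-chlorophenyl takes the place of pyridin-4-yl on a carbonyl carbon. That step also concerns an aromatic ring on a carbonyl, but it was not measured on the oxygen that changes here, so it guides only loosely.

With compound 2 at 22000 nM as the nearest reference, a small move toward lower numbers is expected in this assay, and it may not clear the usual scatter. The expected change is a 1.9-fold lower number from compound 3 to compound 4 (0.27 log units; within the scatter). Compound 4 is estimated at 25000 nM, with an expected range from 10000 nM to 60000 nM.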

Compound 4, half-maximal inhibitory concentration: 25600 nM
The estimate for compound 4 lay 1.0-fold (0.01 log units) below the measured number; the measured number falls inside the stated range.
By their numbers in this assay, from the lowest: compounds 2, 4 and 3 (each within the scatter of the next, the first and the last beyond it). At a limit, above all of these: compound 1.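

In this assay, putting benzoyl in place of hydrogen on the oxygen whose other neighbour is the double-bonded nitrogen gives a 1.8-fold lower number from compound 3 to compound 4 (0.26 log units; within the scatter), so hydroxy and benzoyloxy at this place cannot be told apart in this assay. Among these compounds, compounds 1 and 2 spoke only to the ring on a carbonyl carbon, and this step is the first reading taken at this oxygen itself, where the added benzoyl leaves the number within the scatter. Of the compounds shown, compound 1 alone is reported as a limit: the limit of > 50000 nM in this assay, at which 1 of the 4 values shown sits.

From the compounds shown here alone, it remains open whether an acetyl or a 4-chlorobenzoyl group on this oxygen would give a number set apart from that of compound 3. Also open, going by these compounds, is what a longer chain ending in an amine would do at the same place.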